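Swapping chloro for fluoro on the benzylsulfanyl arm

The source may hold more compounds than are shown below. What is called first, only, known or untested is meant among the compounds shown, and "the series" means these compounds.

Compound 1 `CC1=C(C(=O)Nc2ccc(F)cc2)C(c2ccc([N+](=O)[O-])cc2)N=C(SCc2ccc(Cl)cc2)N1` and compound 2 `CC1=C(C(=O)Nc2ccc(F)cc2)C(c2ccc([N+](=O)[O-])cc2)N=C(SCc2ccc(F)cc2)N1` share one core and differ in a single place: fluoro in place of chloro on an aromatic carbon. In a functional assay on the whole organism (artery, strain albino) with Rattus norvegicus as the target, with a stated time of 120 min, at a dose of 10 mg/kg by the oral route (on this read-out lower numbers stand for less inhibition and higher numbers for more inhibition at the one dose given (going by the name of the read-out)), compound 1 gives 16%, and compound 2 gives 17%, so the step of a number 1 percentage points higher from compound 1 to compound 2 (within the scatter).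

Compound 3 `CC1=C(C(=O)Nc2ccc([N+](=O)[O-])cc2)C(c2ccc(Br)cc2)N=C(SCc2ccc(Cl)cc2)N1` is built on a different core; how its core differs from that of compound 1 is not broken down here. In this assay compound 3 gives 13.9%, a number that lies within the scatter of both compound 1 and compound 2, so no order among the three is claimed.

Compound 4 `CC1=C(C(=O)Nc2ccc([N+](=O)[O-])cc2)C(c2ccc(Br)cc2)N=C(SCc2ccc(F)cc2)N1` has not yet been measured. It stands to compound 3 exactly as compound 2 stands to compound 1: fluoro in place of chloro on an aromatic carbon. Since the place of the change is the same in both pairs, this is the same change. The step from compound 3 to compound 4 in this assay is expected to be a number 1.1 percentage points higher from compound 3 to compound 4 (within the scatter), because the same change between compound 1 and compound 2 gave a number 1 percentage points higher from compound 1 to compound 2 (within the scatter). Compound 4 is therefore estimated at 15%, with a likely range from 6% to 25%.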

Compound 4, a percentage reported as inhibition, in the whole organism at one dose (the size of the read-out at that dose, not a potency): 12.9%
The estimate for compound 4 lay 2.1 percentage points above the measured number; low and high end bracket the measured number.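

On the second core the exchange behaves as it did on the first. In this assay, fluoro in place of chloro on the (4-chlorobenzyl)sulfanyl arm gives a number 1 percentage points lower from compound 3 to compound 4 (within the scatter), and the two steps can be set side by side: the same change on two cores in this assay, a number 1 percentage points higher (within the scatter) from compound 1 to compound 2 and a number 1 percentage points lower (within the scatter) from compound 3 to compound 4, 2 percentage points apart, within the scatter of two such steps.

This shows that, in this read-out at the one dose given, the exchange carries from the core of compound 1 to the core of compound 3 without a step beyond the scatter on either core. It does not show a direction for the change, since the two steps are both too small to give one, and two cores say nothing about how the exchange would behave on any other core in the series.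

The compounds shown leave open whether a group other than these two halogens at this place, such as a methoxy group, an amine or a carboxylic acid, would move the number beyond the scatter. They also leave open whether a longer chain in place of the benzyl arm would do so.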